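A few compounds are considered here, and "the series" means these few. Any claim that something is new, unique, unknown or untested is made for them only; others in the source may bear on it.

Compounds measured so far:
compound 1 `COc1cccc(CN(C)C(=O)c2cc3ccc(-c4cn[nH]c4)cc3[nH]2)c1`
compound 2 `COc1cccc(CNC(=O)c2c[nH]c3cc(-c4cn[nH]c4)ccc23)c1`
compound 3 `COc1cccc(CNC(=O)c2cn(CCN(C)C)c3cc(-c4cn[nH]c4)ccc23)c1`

In an assay on isolated protein for inhibition of Rho-associated protein kinase 2 (Homo sapiens) (on this read-out higher numbers stand for weaker inhibition and lower numbers for stronger inhibition), compound 1 gives 3 nM. For compound 2 the result is a limit of the assay, < 1 nM. For compound 3 likewise only a limit is recorded, < 1 nM. Compound 3 thus sits at the limit of < 1 nM in this assay, at which 2 of the 3 values shown sit, and the step that the two limits leave unreadable from compound 2 to compound 3 cannot be read in size. The next compound, compound 4 `COc1cccc(CNC(=O)c2cn(-c3ccccc3)c3cc(-c4cn[nH]c4)ccc23)c1`, differs from compound 3 by phenyl in place of 2-(dimethylamino)ethyl on an aromatic nitrogen. For the measured compounds named here, no measured step bears directly on this change; the only step recorded at the same position is the unreadable one above. The expected step of an at least 1.5-fold higher number from compound 3 to compound 4 (0.17 log units; that floor lies within the scatter) is therefore small or none beyond the scatter, with a real chance that only a limit is again reported. Compound 4 is estimated at 1.5 nM, between 0.3 nM and 8 nM.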

Compound 4, half-maximal inhibitory concentration: 5 nM
The estimate for compound 4 lay 3.3-fold (0.52 log units) below the measured number, and the stated range covers the measured number.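

Phenyl on the aromatic nitrogen gives the first readable step at this position, an at least 5.0-fold higher number from compound 3 to compound 4 (0.69 log units; beyond the scatter), so the group carried here does register in the read-out, whereas the step to compound 3 from compound 2 cannot be read. Phenyl in place of hydrogen gives an at least 5.0-fold higher number from compound 2 to compound 4 (0.69 log units; beyond the scatter). Both sizes are floors because compound 2 and compound 3 stand at a limit of the assay: the limit of < 1 nM in this assay, at which 2 of the 4 values shown sit.

Open, as far as these compounds go, is whether the aromatic ring of phenyl or the absence of an amine goes with the higher number. A plain ethyl or a cyclohexyl on the same nitrogen would separate the two.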